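The source may report more compounds than this note shows. Statements on the series, on what has been measured and on what is new or still open speak of the compounds shown alone.

Measured so far in a functional assay on MCF7 cells (Homo sapiens) for cytotoxicity, read by sulforhodamine B assay; on this read-out higher numbers stand for an effect only at larger amounts of compound and lower numbers for an effect already at smaller amounts:

Compound 1 `C=C1CC[C@@H]2[C@](C)(CO[Si](C)(C)C(C)(C)C)[C@H](O)CC[C@@]2(C)[C@@H]1C/C=C1/C(=O)OC[C@H]1OC(C)=O` — 10.4 uM
Compound 2 `C=C1CC[C@@H]2[C@](C)(COC(C)=O)[C@H](O)CC[C@@]2(C)[C@@H]1C/C=C1/C(=O)OC[C@H]1OC(C)=O` — 18.5 uM
Compound 3 `C=C1CC[C@@H]2[C@](C)(CO[Si](C(C)C)(C(C)C)C(C)C)[C@H](OC(C)=O)CC[C@@]2(C)[C@@H]1C/C=C1/C(=O)OC[C@H]1OC(C)=O` — 14 uM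

Compound 3 gives the second highest of the three numbers; its nearest neighbour is compound 2 and its furthest is compound 1, and both gaps lie within the scatter, so the three measured compounds cannot be ordered against each other.

Compound 4 `C=C1CC[C@@H]2[C@](C)(CO)[C@H](OC(C)=O)CC[C@@]2(C)[C@@H]1C/C=C1/C(=O)OC[C@H]1OC(C)=O` is not yet measured. It differs from compound 3 at one site: a hydrogen atom in place of a group of 10 heavy atoms (9 carbon, 1 silicon; no ring), on an oxygen on a saturated carbon

For the measured compounds named here, the only measured step on the same oxygen is a 1.8-fold higher number from compound 1 to compound 2 (0.25 log units; within the scatter), where a smaller group took the place of a silicon-bearing group, and the numbers barely moved. Going by the values given here, compound 4 goes further, leaving the oxygen bare, but no measured pair shows that exact change. On the evidence of compound 1 and compound 2 in this assay, the expected outcome is a step of no more than the scatter, if anything towards a slightly higher number.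

For compound 4 the estimate in this assay is 18 uM, with a range of 8 uM to 40 uM, which amounts to an expected step of a 1.3-fold higher number from compound 3 to compound 4 (0.11 log units; within the scatter).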

Compound 4, concentration for half-maximal effect: 11 uM
Compound 4: middle estimate off by 1.6-fold (0.21 log units), on the high side, within the range that was stated.
By their numbers in this assay, from the lowest: compounds 1, 4, 3 and 2 (each within the scatter of the next).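

In this assay, the step to a bare oxygen bearing only a hydrogen atom, with the group of 10 heavy atoms (9 carbon, 1 silicon; no ring) gone, is a 1.3-fold lower number from compound 3 to compound 4 (0.10 log units; within the scatter), so in this pair the silicon-bearing group is not required for the read-out. The earlier step on this oxygen, a 1.8-fold higher number from compound 1 to compound 2 (0.25 log units; within the scatter), only exchanged one group for another, whereas this one shows the same outcome, a step within the scatter, with no group left there at all. No available evidence bears on what lies behind this flat response, and these data give no explanation for it.

Going by these compounds, both readable steps at this position stay within the scatter, so it remains open whether any replacement on this oxygen on a saturated carbon can move the number beyond it. A primary amine, a carboxylic acid or a longer alkyl chain at this oxygen would test that, and the compounds shown do not say whether the result would hold with the other parts of the shared core changed.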